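A few compounds are considered here, and "the series" means these few. Any claim that something is new, unique, unknown or untested is made for them only; others in the source may bear on it.

Compound 1, `CCNC(=O)c1cc(OC2CC2)c(Nc2ncc(Cl)c(Nc3cn(C)nc3S(=O)(=O)C(C)C)n2)cc1C`, gives 82 nM in a functional assay on NCI-H2228 cells (Homo sapiens) for inhibition, read by CellTiter-Glo, with a stated time of 96 h; a lower number here means a stronger inhibitor, a higher number a weaker inhibitor.
Compound 2, `CC(C)S(=O)(=O)c1nn(C)cc1Nc1nc(Nc2ccc(C3CCN(C)CC3)cc2OC2CC2)ncc1Cl`, gives 36 nM in this assay.

Among the two measured compounds, compound 1 stands with the higher number in this assay, and compound 2 sits lower by a gap beyond the usual scatter. Compound 3, `Cc1cc(Nc2ncc(Cl)c(Nc3cn(C)nc3S(=O)(=O)C(C)C)n2)c(OC2CC2)cc1C(=O)C(C)C`, has not been measured. It differs from compound 1 in one place: isopropyl in place of ethylamino on a carbonyl carbon. Going by the values given here, no measured pair shows a change of this kind, so no step can be read off. The step of a 1.6-fold higher number from compound 1 to compound 3 (0.20 log units; within the scatter) is expected to be small, toward a weaker inhibitor, at the edge of the scatter. Compound 3 is estimated at 130 nM, with a range from 50 nM to 350 nM.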

Compound 3, half-maximal inhibitory concentration: 149 nM
Compound 3: middle estimate off by 1.1-fold (0.06 log units), on the low side, within the range that was stated.
By their numbers in this assay, from the lowest: compound 2; then compounds 1 and 3 (each within the scatter of the next).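

In this assay, going by these compounds alone, isopropyl in place of ethylamino on a carbonyl carbon gives a 1.8-fold higher number from compound 1 to compound 3 (0.26 log units; within the scatter) and provides the first reading at this position. The one hydrogen-bond donor of ethylamino leaves and none enters, yet the two values remain within the scatter of each other, so this donor is not shown to matter for the read-out. No evidence available explains this result.

The compounds shown leave open how a carboxylic acid, a morpholine or a longer alkyl chain on this carbonyl carbon would read. They also leave open whether the same change would hold on another core.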